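Amino Replacing Hydrogen on the Core of Compound 1

The compounds below may be only part of what the source reports. "The series", "measured", "known", "first", "only" and "open" are said of these compounds alone.

The account follows a single change on a shared core. Compound 1, `NC(=O)c1ccn(C2O[C@H](CO)[C@@H](O)[C@H]2O)n1`, was tested in a functional assay on Vero cells (Chlorocebus sabaeus); a lower number here means a stronger inhibitor, a higher number a weaker inhibitor. In this assay compound 1 reaches only a limit, > 1030 uM, so no number stands for it. Compound 2, `NC(=O)c1nn([C@@H]2O[C@H](CO)[C@@H](O)[C@H]2O)cc1I`, carries iodine where compound 1 carries hydrogen, and in this assay compound 2 likewise reaches only a limit, > 1350 uM. Both values shown are limits, as the limit of > 1030 uM in this assay, at which 1 of the 2 values shown sits, and the limit of > 1350 uM in this assay, at which 1 of the 2 values shown sits, state, so compound 1 cannot be placed above or below any other compound. Compound 3, `NC(=O)c1nn(C2O[C@H](CO)[C@@H](O)[C@H]2O)cc1N`, differs from compound 1 by amino in place of hydrogen on an aromatic carbon. Among the measured compounds shown here, with no measured step between these compounds, the expected change from compound 1 to compound 3 in this assay is an at least 1.0-fold lower number from compound 1 to compound 3 (0.01 log units; that floor lies within the scatter), that is, none beyond the scatter. Compound 3 is therefore estimated at 1000 uM, within 200 uM to 3000 uM, most likely again reported only as a limit.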

Compound 3, concentration for 50% inhibition: > 1830 uM
Compound 3: only a limit was reported; the forecaster's own chance of this, stated with the estimate: 85%; middle value at least 1.8-fold (0.26 log units) from the limit.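

In this assay compound 3 gives > 1830 uM, which is a limit. Among the compounds shown here, compound 1 also gives only a limit, so no step from it to compound 3 can be read. The compounds shown leave open whether amino in place of hydrogen on an aromatic carbon changes the number at all.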